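The compounds below may be only part of what the source reports. "The series", "measured", "known", "first", "only" and "open" are said of these compounds alone.

Working notes on the series. Within the data shown here, compound 1 `N=C(N)c1ccc(-c2ccc(-c3ccc(Cl)cc3)s2)s1` is the only member for which a number has been recorded: in a functional assay on T47D cells (Homo sapiens) for inhibition, read by sulforhodamine B assay, with a stated time of 48 h (on this read-out lower numbers stand for stronger inhibition of growth and higher numbers for weaker inhibition of growth), compound 1 gives 1550 nM. Two further members stand on record without a result. Compound 2 `N=C(N)c1ccc(-c2ccc(-c3ccccc3)o2)o1` carries in this assay only the entry "not determined" (no result reported). Compound 3 `N=C(N)c1ccc(-c2ccc(-c3ccc(F)cc3)o2)o1` likewise carries in this assay only the entry "not determined" (no result reported). Among the measured compounds shown here, no second number is therefore available, no step between measured compounds can be drawn, and compound 1 stands alone as the sole reference point of the series.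

The next member, compound 4 `N=C(N)c1ccc(-c2ccc(-c3ccc(F)cc3)s2)s1`, keeps the shared core of compound 1 and differs from it in one place: fluoro in place of chloro on an aromatic carbon. The exchange is counted as one heavy atom leaving and one entering, with no ring, no donor and no acceptor involved, and the substituent remains on an aromatic carbon of a six-membered aromatic ring of carbon only.

With compound 1 as the only anchor, the step of a 1.5-fold higher number from compound 1 to compound 4 (0.17 log units; within the scatter) is expected to be small, lying within the usual scatter or at most a slight weakening. Compound 4 is accordingly estimated to reach about 2300 nM in this assay, with a range from 900 nM to 6000 nM.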

Compound 4, concentration for 50% growth inhibition: 1740 nM
For compound 4 the middle estimate is 1.3-fold (0.12 log units) above the measured one; low and high end bracket the measured number.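

In this assay, fluoro in place of chloro on this aromatic carbon, para to a large group, gives a 1.1-fold higher number from compound 1 to compound 4 (0.05 log units; within the scatter) and so does not separate the two compounds. Compound 1 alone could not show whether this position responds to an exchange of one halogen for another; this first step shows that, on the shared core, the exchange from chloro to fluoro leaves the growth-inhibition read-out within the scatter. What this pair supports is limited to these two substituents at this one position, and no measurement at hand gives a reason for the result.

The compounds shown leave open how this position would respond to a group other than these two halogens, such as a methoxy group, an amine or a carboxylic acid, whose readings could mark out how far the present result extends. Among these compounds, also open is whether the same exchange would give a comparable result on another core, since compound 2 and compound 3 carry no result in this assay and offer no second pair.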